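The compounds below may be only part of what the source reports. "The series", "measured", "known", "first", "only" and "open" are said of these compounds alone.

Compound 3 `COc1cc2nccc(Oc3ccc(NC(=O)c4nnc(-c5ccc(F)cc5)o4)cc3)c2cc1OC` is reported in a functional assay on PC-3 cells (Homo sapiens) for antiproliferative activity, read by MTT assay, with a stated time of 72 h (on this read-out lower numbers stand for stronger inhibition and higher numbers for weaker inhibition), only as a limit, > 100000 nM, which is the limit of > 100000 nM in this assay, at which 1 of the 3 values shown sits. Compound 2 `COc1cc2nccc(Oc3ccc(NC(=O)c4ncc(-c5ccc(F)cc5)o4)cc3)c2cc1OC` in this assay gives 21900 nM, so that an at least 4.5-fold higher number from compound 2 to compound 3 (0.65 log units; beyond the scatter). Compound 1 `COc1cc2c(Oc3ccc(NC(=O)c4cc(-c5ccc(F)cc5)on4)cc3)ccnc2cc1OCCCN1CCC(C)CC1` carries the same 5-(4-fluorophenyl)-1,2-oxazol-3-yl amide that compound 4 will carry but a different chain on the shared core; in this assay compound 1 gives 2040 nM. Compound 4 `COc1cc2nccc(Oc3ccc(NC(=O)c4cc(-c5ccc(F)cc5)on4)cc3)c2cc1OC` has not been measured; from compound 3 it differs by 5-(4-fluorophenyl)-1,2-oxazol-3-yl in place of 5-(4-fluorophenyl)-1,3,4-oxadiazol-2-yl on a carbonyl carbon. Among the measured compounds shown here, only one measured step bears on this kind of change, the one from compound 2 to compound 3, which moved toward weaker inhibition when the 1,3-oxazole gave way to the 1,3,4-oxadiazole, and the move here, away from the 1,3,4-oxadiazole, is expected to run the other way in this assay and well beyond the scatter. Compound 1 indicates what the 1,2-oxazole amide can reach, though the core differs in more than this one place. Compound 4 is therefore estimated at 8000 nM, within 2000 nM to 40000 nM, an expected step of an at least 12-fold lower number from compound 3 to compound 4 (1.09 log units; beyond the scatter).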

Compound 4, half-maximal inhibitory concentration: 29400 nM
Compound 4: middle estimate off by 3.7-fold (0.57 log units), on the low side; the measured number falls inside the stated range.
By their numbers in this assay, from the lowest: compound 1; then compounds 2 and 4 (each within the scatter of the next). At a limit, above all of these: compound 3.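

In this assay, the 5-(4-fluorophenyl)-1,2-oxazol-3-yl group on the carbonyl carbon gives an at least 3.4-fold lower number from compound 3 to compound 4 (0.53 log units; beyond the scatter), so this step, like the one to the 1,3-oxazole, leaves the 5-(4-fluorophenyl)-1,3,4-oxadiazol-2-yl amide behind with a lower number. Compound 3 stands only as a limit, so that step has no exact size: the limit of > 100000 nM in this assay, at which 1 of the 4 values shown sits. The two oxazole amides cannot be told apart, with a 1.3-fold higher number from compound 2 to compound 4 (0.13 log units; within the scatter), whereas the 2-(4-methylpiperidin-1-yl)ethyl chain in place of hydrogen accounts for a much larger difference, a 14-fold higher number from compound 1 to compound 4 (1.16 log units; beyond the scatter).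

Going by these compounds, whether that chain would lower the number to a similar extent with the 1,3-oxazole amide remains open. So does whether a morpholine or a primary amine at the end of the chain would do the same.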